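Removing a methoxy group from a pyridyl pyrazole chalcone

This account rests on a few compounds, and the source may have more. Where it says the series, first, only, none or still open, it means among the compounds named here.

Compound 1 `COc1cc(C(=O)/C=C/c2cn(-c3ccccc3)nc2-c2cccnc2)cc(OC)c1OC` and compound 2 `COc1ccc(C(=O)/C=C/c2cn(-c3ccccc3)nc2-c2cccnc2)cc1OC` were tested in a functional assay on HCT-116 cells (Homo sapiens) for inhibition, read by sulforhodamine B assay, with a stated time of 72 h; a higher number here means a weaker inhibitor, a lower number a stronger inhibitor. Compound 1 gives 8600 nM, and compound 2 gives 4300 nM. The change between them, (hydrogen in place of methoxy on an aromatic carbon), made the step of a 2.0-fold lower number from compound 1 to compound 2 (0.30 log units; within the scatter). Compound 3 `COc1ccc(C(=O)/C=C/c2cn(-c3ccccc3)nc2-c2ccncc2)c(OC)c1OC` carries a different core; how its core differs from that of compound 1 is not broken down here, and in this assay compound 3 gives 1300 nM. Compound 4 `COc1ccc(C(=O)/C=C/c2cn(-c3ccccc3)nc2-c2ccncc2)cc1OC` has not been measured in this assay. It arises from compound 3 by hydrogen in place of methoxy on an aromatic carbon, the same kind of change as that from compound 1 to compound 2, though here the place is ortho to a large group rather than meta to it. Because the earlier step was a 2.0-fold lower number from compound 1 to compound 2 (0.30 log units; within the scatter), a step of similar size is expected here, namely a 1.3-fold lower number from compound 3 to compound 4 (0.11 log units; within the scatter). For compound 4 the expected value in this assay is 1000 nM, between 400 nM and 3000 nM.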

Compound 4, half-maximal inhibitory concentration: 1200 nM
Compound 4: middle estimate off by 1.2-fold (0.08 log units), on the low side, within the range that was stated.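

Hydrogen in place of methoxy gives a 1.1-fold lower number from compound 3 to compound 4 (0.03 log units; within the scatter) in this assay, and the change carries across the two cores without a difference that can be told from the scatter: the same change on two cores in this assay, a 2.0-fold lower number (0.30 log units; within the scatter) from compound 1 to compound 2 and a 1.1-fold lower number (0.03 log units; within the scatter) from compound 3 to compound 4, 1.8-fold (0.27 log units) apart, within the scatter of two such steps. For the compounds shown here, this shows only that the change left the number within the scatter on both cores, and two pairs, with the methoxy leaving from different places, give no rule for other cores. The step that does exceed the scatter is a different change, pyridin-4-yl in place of pyridin-3-yl, with a 3.6-fold lower number from compound 2 to compound 4 (0.55 log units; beyond the scatter) on a single pair.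

Going by these compounds, what an amine, a hydroxyl or a longer chain such as ethoxy would do in place of that methoxy stays open. On these data alone, whether the pyridin-4-yl step holds on other cores also stays open.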